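The compounds below may be only part of what the source reports. "The series", "measured", "known", "first", "only" and "open" are said of these compounds alone.

Three measured compounds share one core and differ only in the group carried on the quaternary ring nitrogen. Compound 1 `CC(C)(C)C[N+]1(C)CCc2c(sc(NC(=O)Nc3ccc(Cl)cc3)c2C(N)=O)C1` gives 290 nM in a functional assay (strain AB) with Danio rerio as the target, read by microscopy, with a stated time of 1 h; on this read-out higher numbers stand for an effect only at larger amounts of compound and lower numbers for an effect already at smaller amounts. Compound 2 `CC[N+]1(C)CCc2c(sc(NC(=O)Nc3ccc(Cl)cc3)c2C(N)=O)C1` gives 1960 nM, and compound 3 `CC(C)(C)OC(=O)CCC[N+]1(C)CCc2c(sc(NC(=O)Nc3ccc(Cl)cc3)c2C(N)=O)C1` gives 250 nM. Compound 2 therefore stands with the highest number of the three: one step is a 6.8-fold higher number from compound 1 to compound 2 (0.83 log units; beyond the scatter), and the other is a 7.8-fold lower number from compound 2 to compound 3 (0.89 log units; beyond the scatter), both beyond the scatter, while compounds 1 and 3 lie within the scatter of each other, as a 1.2-fold lower number from compound 1 to compound 3 (0.06 log units; within the scatter) shows.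

Compound 4 `CC[N+]1(CC2CC2)CCc2c(sc(NC(=O)Nc3ccc(Cl)cc3)c2C(N)=O)C1` is not yet measured. It differs from compound 2 by cyclopropyl in place of hydrogen on a saturated chain carbon bound to an amine nitrogen in a ring.

Among the compounds with values here, two measured steps bear on this change. Replacing tert-butyl with methyl on that chain carbon, from compound 1 to compound 2, raised the number modestly, and adding a (tert-butoxycarbonyl)methyl group two bonds along the chain, from compound 2 to compound 3, lowered it by a similar amount. Both point the same way: a larger group on the chain attached to the ring nitrogen goes with a lower number than the ethyl of compound 2. The cyclopropyl entering here is smaller than either tert-butyl or the ester chain, so a somewhat smaller step is expected. The expected step is a 3.6-fold lower number from compound 2 to compound 4 (0.55 log units; beyond the scatter), in the direction of a lower number. Compound 4 is thus estimated at 550 nM, with a range from 220 nM to 1400 nM.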

Compound 4, half-maximal effective concentration: 100 nM
For compound 4 the middle estimate is 5.5-fold (0.74 log units) above the measured one, and the stated range ends above it.
By their numbers in this assay, from the lowest: compound 4; then compounds 3 and 1 (each within the scatter of the next); then compound 2.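

In this assay, within the data shown here, the change from methyl to cyclopropylmethyl, with cyclopropyl in place of hydrogen on a saturated chain carbon bound to an amine nitrogen in a ring, gives a 20-fold lower number from compound 2 to compound 4 (1.29 log units; beyond the scatter) and is the only large step in the set. The earlier steps from and to compound 2 were both modest, and this one shows that cyclopropyl, with its 3 heavy atoms, moves the number further than the bigger (tert-butoxycarbonyl)methyl addition, which gave a 7.8-fold lower number from compound 2 to compound 3 (0.89 log units; beyond the scatter), so among these two steps the number of atoms added does not set the size of the step. Nothing available here accounts for this result.

The compounds shown leave open whether the three-membered ring itself matters or whether any chain of similar length would do, a question that an open n-butyl or isobutyl chain on that carbon, or a cyclobutyl ring in place of cyclopropyl, would address. They also leave open how a carboxylic acid or an amine at the end of the chain would read out in this position.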